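From 3-methoxyphenyl to 3,4-dimethoxyphenyl

The source may report more compounds than this note shows. Statements on the series, on what has been measured and on what is new or still open speak of the compounds shown alone.

In a functional assay on HepG2 cells (Homo sapiens) for inhibition, read by MTT assay, with a stated time of 24 h (a higher number here means a weaker inhibitor of growth, a lower number a stronger inhibitor of growth), compound 1 `COc1ccc2c(c1)c(-c1nc3ccccc3n1C(=O)c1ccccc1)cn2C` gives 37900 nM, compound 2 `COc1ccc2c(c1)c(-c1nc3ccccc3n1C(=O)c1ccccc1OC)cn2C` gives 23600 nM and compound 3 `COc1cccc(C(=O)n2c(-c3cn(C)c4ccc(OC)cc34)nc3ccccc32)c1` gives 11700 nM. Compound 3 thus stands clearly under compound 1, with a 3.2-fold lower number from compound 1 to compound 3 (0.51 log units; beyond the scatter), but is not separated from compound 2, with a 2.0-fold lower number from compound 2 to compound 3 (0.30 log units; within the scatter).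

Compound 4 `COc1ccc2c(c1)c(-c1nc3ccccc3n1C(=O)c1ccc(OC)c(OC)c1)cn2C` takes compound 3 one step further: methoxy in place of hydrogen on an aromatic carbon. This methoxy in place of hydrogen on an aromatic carbon turns 3-methoxyphenyl into 3,4-dimethoxyphenyl. The closest guides are the two measured methoxy additions, a 1.6-fold lower number from compound 1 to compound 2 (0.21 log units; within the scatter) and a 3.2-fold lower number from compound 1 to compound 3 (0.51 log units; beyond the scatter). One stays within the scatter and the other is modest, both pointing to lower numbers. Among the measured compounds shown here, neither adds a second methoxy to a ring that already carries one, so the data offer no direct precedent. A small move in the same direction, not beyond the scatter, is therefore expected, namely a 1.2-fold lower number from compound 3 to compound 4 (0.07 log units; within the scatter). For compound 4 the estimated value is 10000 nM, with an expected range of 4500 nM to 23000 nM.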

Compound 4, concentration for 50% growth inhibition: 5100 nM
Compound 4: the middle estimate sits 2.0-fold (0.29 log units) above what was measured; measured number inside the range.
By their numbers in this assay, from the lowest: compound 4; then compounds 3, 2 and 1 (each within the scatter of the next, the first and the last beyond it).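

In this assay, a ring that already carries a methoxy still responds to a second one: the new methoxy, ortho to a methoxy group and para to a large group, lowers the number beyond the scatter (a 2.3-fold lower number from compound 3 to compound 4 (0.36 log units; beyond the scatter)). With 3,4-dimethoxyphenyl on the carbonyl carbon, compound 4 is the strongest inhibitor of growth of the four, clear of both the 2-methoxyphenyl compound (a 4.6-fold lower number from compound 2 to compound 4 (0.67 log units; beyond the scatter)) and the phenyl compound (a 7.4-fold lower number from compound 1 to compound 4 (0.87 log units; beyond the scatter)). The two steps that add a methoxy, at different places on the ring, do not differ in size beyond the scatter: the same change on two cores in this assay, a 1.6-fold lower number (0.21 log units; within the scatter) from compound 1 to compound 2 and a 2.3-fold lower number (0.36 log units; beyond the scatter) from compound 3 to compound 4, 1.4-fold (0.15 log units) apart, within the scatter of two such steps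

As far as these compounds go, whether a methoxy at this new place would lower the number equally on the plain phenyl ring of compound 1 remains open. So does the effect of an amine, a carboxylic acid or a longer chain such as ethoxy there.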